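Bromo in place of chloro on compound 3

A few compounds are considered here, and "the series" means these few. Any claim that something is new, unique, unknown or untested is made for them only; others in the source may bear on it.

Measured in a functional assay on MCF7 cells (Homo sapiens) for antiproliferative activity, read by MTT assay, with a stated time of 48 h; a higher number here means a weaker inhibitor, a lower number a stronger inhibitor
Compound 1 `Brc1ccc2[nH]c(-c3cn(-c4ccccc4)nc3-c3ccccc3)nc2c1` gives 830 nM
Compound 2 `Clc1ccc(-c2nn(-c3ccccc3)cc2-c2nc3cc(Br)ccc3[nH]2)cc1` gives 1920 nM
Compound 3 `COc1ccc(-c2nn(-c3ccccc3)cc2-c2nc3cc(Cl)ccc3[nH]2)cc1` gives 1760 nM

The number for compound 3 lies within the usual scatter of that for compound 2, and beyond the scatter above that for compound 1. Compound 4 `COc1ccc(-c2nn(-c3ccccc3)cc2-c2nc3cc(Br)ccc3[nH]2)cc1` differs from compound 3 in one place (bromo in place of chloro on an aromatic carbon): bromo in place of chloro on an aromatic carbon. For the measured compounds named here, the only measured single change is modest (a 2.3-fold higher number from compound 1 to compound 2 (0.36 log units; beyond the scatter)) and puts chloro in place of hydrogen, so it bears only weakly on this swap. Going by the values given here, no measured pair exchanges chloro for bromo. Compound 2 also carries bromo on the core and gives a similar number (1920 nM). In this assay no step beyond the scatter is therefore expected, and the estimated step is small (a 1.0-fold higher number from compound 3 to compound 4 (0.01 log units; within the scatter)). The estimated value for compound 4 is 1800 nM (range 900 nM to 3500 nM).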

Compound 4, half-maximal inhibitory concentration: 1830 nM
Beside the measured number, compound 4's estimate is 1.0-fold (0.01 log units) below it, and the stated range covers the measured number.
By their numbers in this assay, from the lowest: compound 1; then compounds 3, 4 and 2 (each within the scatter of the next).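

In this assay, bromo in place of chloro on the fused ring system gives a 1.0-fold higher number from compound 3 to compound 4 (0.02 log units; within the scatter), so the two halogens cannot be told apart at this position when methoxy is present. Methoxy in place of chloro gives a 1.0-fold lower number from compound 2 to compound 4 (0.02 log units; within the scatter), also within the scatter, while methoxy in place of hydrogen gives a 2.2-fold higher number from compound 1 to compound 4 (0.34 log units; beyond the scatter), a modest step in the same direction as a 2.3-fold higher number from compound 1 to compound 2 (0.36 log units; beyond the scatter). No measurement here explains these steps. On these data alone, it remains open whether fluoro or an amine at the bromo position would also stay within the scatter, and how a longer chain or a carboxylic acid in place of methoxy would behave.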